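Swapping Methyl for Chloro: What the Numbers Suggest

This account rests on a few compounds, and the source may have more. Where it says the series, first, only, none or still open, it means among the compounds named here.

Compound 1 `CCOc1ccc(C(=O)/C=C/c2ccc(N(C)C)cc2)cc1` and compound 2 `CCOc1ccc(C(=O)/C=C/c2ccc(C)cc2)cc1` share one core and differ in a single group on an aromatic carbon. In an assay on isolated protein for inhibition of Amine oxidase [flavin-containing] B (Homo sapiens) (a lower number here means a stronger inhibitor, a higher number a weaker inhibitor), compound 1 gives 210 nM, and compound 2 gives 210 nM. The step of no change at the digits printed from compound 1 to compound 2 (within the scatter) shows that exchanging dimethylamino for methyl left the measured inhibition unchanged within the scatter, so compound 2 stands level with compound 1 on the numbers at hand.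

Compound 3 `CCOc1ccc(C(=O)/C=C/c2ccc(Cl)cc2)cc1` differs from compound 2 by chloro in place of methyl on an aromatic carbon. Within the data shown here, only one measured step touches this position, the exchange from compound 1 to compound 2, and it was flat: no change at the digits printed from compound 1 to compound 2 (within the scatter). Among the measured compounds shown here, no measured step exchanges a methyl for a halogen, so the evidence for this particular change is thin. Given that the one step at this position stayed within the scatter, compound 3 is expected to land near compound 2, at about 200 nM, with a plausible range from 80 nM to 500 nM. The expected step of a 1.1-fold lower number from compound 2 to compound 3 (0.02 log units; within the scatter) is therefore no change beyond the scatter.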

Compound 3, half-maximal inhibitory concentration: 210 nM
Estimate against measurement, compound 3: 1.1-fold (0.02 log units) below; low and high end bracket the measured number.
By their numbers in this assay, from the lowest: compounds 1, 2 and 3 (each within the scatter of the next).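

Chloro in place of methyl gives no change at the digits printed from compound 2 to compound 3 (within the scatter) in this assay, and this is the first exchange at this position that brings in a halogen. Chloro in place of dimethylamino gives no change at the digits printed from compound 1 to compound 3 (within the scatter), so the flat reading no longer rests on a single pair: all three pairs among dimethylamino, methyl and chloro, on an aromatic carbon para to a large group, fall within the scatter. So three groups built from different atoms have now been compared at this one place without the number separating them, but nothing available here explains why these three groups read alike.

The compounds shown leave open whether this flat picture holds for groups of other kinds at the same position, such as a carboxylic acid, a primary amine, a hydroxyl or a longer chain like butyl, any of which could separate from these three or could read the same. They also leave open whether the same exchanges would stay as flat on a different part of the shared core, or with the ethoxy group replaced.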